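The source may hold more compounds than are shown below. What is called first, only, known or untested is meant among the compounds shown, and "the series" means these compounds.

Compound 1 `CCN(CC)CCCn1c(=O)/c(=C/c2ccc(F)c(F)c2)s/c1=C1/C(=O)Nc2ccc(F)cc21`: 13400 nM
Compound 2 `CN(C)CCn1c(=O)/c(=C/c2ccc(O)cc2)s/c1=C1\C(=O)Nc2ccc(F)cc21`: 1300 nM

Both numbers come from a functional assay on K562 cells (Homo sapiens) for cytotoxicity, read by sulforhodamine B assay, with a stated time of 48 h; a higher number here means a weaker inhibitor, a lower number a stronger inhibitor. Compound 2 holds the lower number of the two, 1300 nM, and the gap up to compound 1 lies beyond the usual scatter.

Compound 3 `CN(C)CCn1c(=O)/c(=C/c2ccc(O)cc2)s/c1=C1/C(=O)Nc2ccc(F)cc21` has the same parts as compound 2: the two compounds have the same atoms and bonds and differ only in configuration as drawn: 1 of 2 stereo elements differ; a double bond is drawn Z in compound 2 and E in compound 3. For the measured compounds named here, no measured pair here shows what such a change does in this assay, so no step beyond the scatter is expected. The estimated step, a 1.4-fold higher number from compound 2 to compound 3 (0.14 log units; within the scatter), is therefore expected to be small. For compound 3 the expected value is 1800 nM, with an estimated range of 600 nM to 6000 nM.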

Compound 3, half-maximal inhibitory concentration: 1300 nM
Estimate against measurement, compound 3: 1.4-fold (0.14 log units) above; measured number inside the range.
By their numbers in this assay, from the lowest: compounds 2 and 3 (each within the scatter of the next); then compound 1.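

Changing one double bond from Z to E brings no change at the digits printed from compound 2 to compound 3 (within the scatter) in this assay. For the compounds shown here, this is the first pair here that differs in one place only, so it tests a single feature on its own: the fact that compounds 2 and 3 differ only in the configuration as drawn. For this pair, then, the way this double bond is drawn makes no difference that the assay can detect.

Going by these compounds, it remains open whether the other double bond would behave in the same way. On these data alone, it is also open whether this result would hold with a different amine, such as a morpholine in place of the dimethylamino group.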